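This account rests on a few compounds, and the source may have more. Where it says the series, first, only, none or still open, it means among the compounds named here.

Measured compounds in this series:
- compound 1 `CCCC(=O)N(Cc1ccccc1)C1CCN(S(=O)(=O)c2c(C)cc(C)cc2C)CC1`: in a functional assay on DLD-1 cells (Homo sapiens) for antiproliferative activity, read by CellTiter-Glo, with a stated time of 72 h (a higher number here means a weaker inhibitor, a lower number a stronger inhibitor), compound 1 gives > 5000 nM, which is a limit of the assay and not a number.
- compound 2 `Cc1cc(C)c(S(=O)(=O)N2CCC(N3CCC(C)CC3)CC2)c(C)c1`: compound 2 gives 0.03 nM.
- compound 3 `Cc1cc(C)c(S(=O)(=O)c2ccc(N3CCC(C)CC3)cc2)c(C)c1`: compound 3 gives > 5000 nM, again a limit and not a number.

Going by the values given here, compound 2 is thus the only one of the three measured compounds that returns a number at all; the other two stop at the limit of > 5000 nM in this assay, at which 2 of the 3 values shown sit, so no measured step of known size exists in this set, and nothing can be said of the gap from compound 2 to either of them beyond the fact that it is large.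

Compound 4 `Cc1cc(C)c(S(=O)(=O)N2CCC(N3CCC(C(C)C)CC3)CC2)c(C)c1` has not yet been measured. It differs from compound 2 by isopropyl in place of methyl on a saturated ring carbon. Among the compounds with values here, with no measured step to lean on, only the smallness of the change guides the expectation: a step from compound 2 to compound 4 that stays close to the scatter, perhaps leaning toward a weaker inhibitor. The expected step is a 3.3-fold higher number from compound 2 to compound 4 (0.52 log units; beyond the scatter). For compound 4 the estimate in this assay is 0.1 nM, with a range from 0.02 nM to 1 nM.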

Compound 4, half-maximal inhibitory concentration: 0.3 nM
Compound 4: middle estimate off by 3.0-fold (0.48 log units), on the low side; the range from low to high includes it.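

In this assay, going by these compounds alone, the change from 4-methylpiperidin-1-yl to 4-isopropylpiperidin-1-yl gives the first step of known size: a 10-fold higher number from compound 2 to compound 4 (1.00 log units; beyond the scatter). The number therefore responds to the group on this saturated ring carbon, yet compound 4 with its isopropyl group still gives a measured value of 0.3 nM, so this position accepts a group of 3 carbon atoms without the activity being lost. No measured property at hand accounts for the size of this step.

On these data alone, with only methyl and isopropyl at this position, one step gives no trend, and it stays open whether an ethyl group would fall between them. A tert-butyl group, a longer chain, an amine or a carboxylic acid on the same carbon could each extend or break this picture.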